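Three Compounds at the Limit and a Fourth to Come

The compounds below may be only part of what the source reports. "The series", "measured", "known", "first", "only" and "open" are said of these compounds alone.

Three measured compounds share one core and differ at two points. Compound 1 `Cc1ccc2[nH]c(=O)c(-c3nc4cc([N+](=O)[O-])ccc4[nH]3)cc2c1` carries a methyl group and a nitro group. Compound 2 `COc1ccc2[nH]c(=O)c(-c3nc4cc([N+](=O)[O-])ccc4[nH]3)cc2c1` carries a methoxy group where compound 1 carries the methyl. Compound 3 `Cc1ccc2[nH]c(=O)c(-c3nc4cc(Br)ccc4[nH]3)cc2c1` carries a bromo group where compound 1 carries the nitro. The unmeasured compound 4 `COc1ccc2[nH]c(=O)c(-c3nc4cc(Br)ccc4[nH]3)cc2c1` carries both the methoxy and the bromo group.

In a functional assay on HepG2 cells (Homo sapiens) for cytotoxicity, read by MTT assay, with a stated time of 48 h (a higher number here means a weaker inhibitor, a lower number a stronger inhibitor), compound 1 gives > 100000 nM, which is a limit of the assay rather than a number. In this assay compound 2 gives > 100000 nM, also a limit. In this assay compound 3 gives > 100000 nM, again a limit. Because (the limit of > 100000 nM in this assay, at which 3 of the 3 values shown sit), neither a step that the two limits leave unreadable from compound 1 to compound 2 nor a step that the two limits leave unreadable from compound 1 to compound 3 can be sized.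

The change from compound 1 to compound 2 is methoxy in place of methyl on an aromatic carbon. The change from compound 3 to compound 4 is methoxy in place of methyl on an aromatic carbon, and its place is described in exactly the same words, so it is the same change made on a different core. The two cores differ by bromo in place of nitro on an aromatic carbon.

The expectation for compound 4 rests on compound 3, which gives > 100000 nM, a limit. It also rests on compound 2, which after the same change gives > 100000 nM, a limit. The step is expected to be a step that the limit leaves unreadable from compound 3 to compound 4. Compound 4 is therefore estimated at 150000 nM, most likely between 50000 nM and 500000 nM, and most likely reported only as a limit.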

Compound 4, half-maximal inhibitory concentration: > 100000 nM
Compound 4 ended at the assay's limit (the forecaster's own chance of this, stated with the estimate: 85%); the middle value is on the limit's open side.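

In this assay compound 4 gives > 100000 nM, which is a limit and not a number. Neither the step from compound 3 to compound 4 nor the step from compound 2 to compound 4 can be read, because all four compounds rest at one limit: the limit of > 100000 nM in this assay, at which 4 of the 4 values shown sit.

The compounds shown leave open how far each one lies past that limit, and so whether swapping methyl for methoxy or nitro for bromo changes the reading at all.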